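The compounds below may be only part of what the source reports. "The series", "measured", "known", "first", "only" and "open" are said of these compounds alone.

In a functional assay on 8305C cells (Homo sapiens) for cytotoxicity, read by MTT assay, with a stated time of 24 h (on this read-out lower numbers stand for stronger inhibition and higher numbers for weaker inhibition), compound 1, `CN1O[C@@H](n2ccnn2)C[C@@H]1CO`, gives 7960 nM, and compound 2, `CCCc1cn([C@H]2C[C@H](CO)N(C)O2)nn1`, gives 5820 nM. Among the compounds with values here, compound 2 holds the lowest of the two numbers on hand, but the only measured step, a 1.4-fold lower number from compound 1 to compound 2 (0.14 log units; within the scatter), lies within the scatter, so the two compounds cannot be told apart on these data. Compound 3, `CCCc1cn([C@@H]2C[C@H](CO)N(C)O2)nn1`, has not yet been measured. It differs from compound 2 in this way: the two compounds have the same atoms and bonds and differ only in configuration as drawn: 1 of 2 stereo elements differ; a stereocentre at a saturated ring carbon is drawn R in compound 2 and S in compound 3. Within the data shown here, no measured step bears on a change of this kind. Among the measured compounds shown here, the single step available concerns a propyl group entering an aromatic carbon and says nothing about what happens when the configuration at a saturated ring carbon is changed. For the measured compounds named here, the data therefore offer no direction and no size for the step ahead; a change of configuration alone can move a number either way, and nothing here weighs one way over the other. The step from compound 2 to compound 3 is thus expected to be a 1.1-fold higher number from compound 2 to compound 3 (0.05 log units; within the scatter), with a wide range around it. Compound 3 is estimated at 6500 nM, between 2000 nM and 25000 nM.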

Compound 3, half-maximal inhibitory concentration: 6870 nM
Compound 3: middle estimate off by 1.1-fold (0.02 log units), on the low side, and the stated range covers the measured number.
By their numbers in this assay, from the lowest: compounds 2, 3 and 1 (each within the scatter of the next).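

Changing the configuration at the saturated ring carbon from R to S gives, in this assay, a 1.2-fold higher number from compound 2 to compound 3 (0.07 log units; within the scatter). Within the data shown here, this is the first look at configuration at this position: with the propyl group in place and everything else held constant, the R and S forms cannot be told apart on this read-out, and the earlier step, which concerned only the propyl group on the aromatic carbon, could not show this. The comparison bears on this one stereocentre and on nothing else in the structure: the fact that compounds 2 and 3 differ only in the configuration as drawn.

As far as these compounds go, it remains open whether the configuration at this carbon would matter as little with hydrogen on the aromatic carbon, or with a longer chain, an amine or a carboxylic acid in place of the propyl group, and the effect of changing the second stereo element is also unknown. Since neither of the two steps shown moves the number beyond the scatter, it also remains open which part of the structure, if any, governs the cytotoxicity seen on these cells.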